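Aminocyclohexyl to aminophenyl swap on the shared core

The compounds below may be only part of what the source reports. "The series", "measured", "known", "first", "only" and "open" are said of these compounds alone.

Working notes on a small set around one shared core. Compound 1 `N[C@H]1CC[C@H](Nc2c(C(=O)NCc3ccccn3)nc(Br)c3cccnc23)CC1` carries a 4-aminocyclohexyl group on the ring nitrogen, and in a functional assay on HCT-116 cells (Homo sapiens) for cytotoxicity, read by MTT assay, with a stated time of 72 h (on this read-out lower numbers stand for stronger inhibition and higher numbers for weaker inhibition), compound 1 stands as "not determined" (no result reported), with no number reported. Going by the values given here, compound 2 `N[C@H]1CC[C@H](Nc2c(C(=O)NCc3ccc(F)cc3)nc(Br)c3cccnc23)CC1` keeps that group and, in this assay, compound 2 gives 7000 nM; this is the only number available in the set, so compound 2 cannot be ranked against anything else.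

Compound 3 `Nc1cccc(Nc2c(C(=O)NCc3ccc(F)cc3)nc(Br)c3cccnc23)c1` is not yet measured. Its change from compound 2 is 3-aminophenyl in place of 4-aminocyclohexyl on a nitrogen on an aromatic ring. Among the compounds with values here, no step between two measured compounds is known, so nothing in the data shows how such a change moves this read-out. The expectation is a step from compound 2 to compound 3 of a 1.4-fold higher number from compound 2 to compound 3 (0.15 log units; within the scatter), probably no larger than the scatter and, if anything, toward weaker inhibition. Compound 3 is therefore estimated at 10000 nM, with a range from 2500 nM to 40000 nM.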

Compound 3, half-maximal inhibitory concentration: > 10000 nM
Compound 3 ended at the assay's limit; the forecaster's own chance of this, stated with the estimate: 20%; the middle value lies on the limit itself.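

In this assay compound 3 gives > 10000 nM, which is a limit of the assay and not a number. Taken as a step, 3-aminophenyl in place of 4-aminocyclohexyl on a nitrogen on an aromatic ring gives an at least 1.4-fold higher number from compound 2 to compound 3 (0.15 log units; that floor lies within the scatter), so this first step at the position shows no move toward stronger inhibition, while its true size stays unknown. Only a floor can be read for this change, which leaves the step open-ended on the side of weaker inhibition: the limit of > 10000 nM in this assay, at which 1 of the 3 values shown sits.

As far as these compounds go, how far compound 3 lies past its limit remains open, and so does any reading of the 4-aminocyclohexyl group against a ring without the amine. Also open, from the compounds shown here alone, is how a 4-hydroxycyclohexyl group, a straight aminoalkyl chain or a carboxylic acid in place of the amine would read on this nitrogen.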